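The compounds below may be only part of what the source reports. "The series", "measured", "known", "first", "only" and "open" are said of these compounds alone.

Compound 1 `COc1cc(-c2cc(-c3cc(C(C)C)c(O)cc3C)[nH]c(=O)c2C#N)cc(OC)c1OC` gives 35% in a functional assay for inhibition, tested at 20 ug/mL; on this read-out higher numbers stand for a stronger effect at the one concentration tested and lower numbers for a weaker effect.
Compound 2 `COc1ccc(-c2cc(-c3cc(C(C)C)c(O)cc3C)[nH]c(=O)c2C#N)cc1` gives 24% in this assay.
Compound 3 `COc1cc(OC)c(-c2cc(-c3cc(C(C)C)c(O)cc3C)[nH]c(=O)c2C#N)c(OC)c1` gives 32% in this assay.

All three share a common core and differ only in the aromatic ring attached to it. Compound 2 has the lowest of the three numbers. Its nearest neighbour is compound 3, and that gap lies within the usual scatter, so the two cannot be told apart. Compound 1 stands higher than compound 2 by a gap beyond the scatter.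

Compound 4 `Cc1cc(O)c(C(C)C)cc1-c1cc(-c2ccccc2Cl)c(C#N)c(=O)[nH]1` has not yet been measured in this assay. Set against compound 2, the change is 2-chlorophenyl in place of 4-methoxyphenyl on an aromatic carbon. Within the data shown here, no pair of measured compounds shows this change, so its effect is not known from the data here. The three measured compounds, which differ in the same ring, spread over a modest range, so only a small step is expected in this assay, in either direction or none beyond the scatter. The step from compound 2 to compound 4 is expected to be a number 4 percentage points higher from compound 2 to compound 4 (within the scatter). Compound 4 is estimated to give 28%, between 10% and 48%.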

Compound 4, a percentage reported as inhibition, at one concentration (the size of the read-out at that concentration, not a potency): 12%
For compound 4 the middle estimate is 16 percentage points above the measured one, within the range that was stated.
By their numbers in this assay, from the lowest: compound 4; then compounds 2, 3 and 1 (each within the scatter of the next, the first and the last beyond it).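

The change to 2-chlorophenyl gives a number 12 percentage points lower from compound 2 to compound 4 (beyond the scatter) in this assay and so shows that the read-out can fall when this ring, opposite the ring nitrogen, loses its methoxy groups. Compounds 1, 2 and 3 all carry methoxy groups on this ring, whereas compound 4 is the only one here with a chlorine, and its change replaces the substituent and also moves it to a different place on the ring. Nothing shown here gives a measured reason for this step.

On these data alone, it remains open whether the chlorine or its place on the ring matters more, a question that a pair such as 4-chlorophenyl and 2-methoxyphenyl could address. As far as these compounds go, how this position would respond to a ring bearing an amine or a carboxylic acid also remains unknown.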